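The source may hold more compounds than are shown below. What is called first, only, known or untested is meant among the compounds shown, and "the series" means these compounds.

Measured in a functional assay on A2780 cells (Homo sapiens) for inhibition, read by sulforhodamine B assay, with a stated time of 3 days; on this read-out higher numbers stand for weaker inhibition and lower numbers for stronger inhibition:

- Compound 1 `O=C1Nc2ccc(F)cc2/C1=C\C(=O)c1ccc(O)cc1F`: 1580 nM
- Compound 2 `O=C1Nc2ccc(F)cc2/C1=C\C(=O)c1ccc(C2CCCCC2)cc1`: 2310 nM
- Compound 3 `COc1ccc(C(=O)Nc2ccc3c(c2)/C(=C/Nc2cccc(N4CCN(C)CC4)c2)C(=O)N3)cc1`: 2050 nM

Compound 3 lies within the usual scatter of both compound 1 and compound 2, so these three values cannot be ranked. The next compound to be tested is compound 4 `CN1CCN(c2cccc(N/C=C3\C(=O)Nc4ccc(NC(=O)c5c(Cl)cccc5Cl)cc43)c2)CC1`. For the measured compounds named here, it carries 2,6-dichlorophenyl in place of 4-methoxyphenyl on a carbonyl carbon, the only difference from compound 3: 2,6-dichlorophenyl in place of 4-methoxyphenyl on a carbonyl carbon.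

Going by the values given here, no two measured compounds differ in a single place, so the data hold no direct measure of this change. The best available anchor is the closest relative, compound 3 at 2050 nM. No step beyond the scatter is therefore expected in this assay, and no firm direction can be given. The expected step is a 1.4-fold lower number from compound 3 to compound 4 (0.14 log units; within the scatter). For compound 4 the estimated value is 1500 nM, with an expected range of 350 nM to 6000 nM.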

Compound 4, half-maximal inhibitory concentration: 2140 nM
Beside the measured number, compound 4's estimate is 1.4-fold (0.15 log units) below it; the measured number falls inside the stated range.
By their numbers in this assay, from the lowest: compounds 1, 3, 4 and 2 (each within the scatter of the next).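

In this assay, for the compounds shown here, the exchange of 4-methoxyphenyl for 2,6-dichlorophenyl on the carbonyl carbon gives a 1.0-fold higher number from compound 3 to compound 4 (0.02 log units; within the scatter) and so provides the first direct reading of a change at this position. This step lies within the scatter, so the two groups cannot be told apart here, even though the oxygen and its hydrogen-bond acceptor leave and two chlorines enter. No measurement shown explains why the values stay so close.

Going by these compounds alone, this single step covers only two substituted phenyl rings, so it cannot show whether the position tolerates change in general. A carboxylic acid, a dimethylamino group or a longer alkyl chain in place of these rings could give a different value, and the compounds shown do not settle this.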